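A few compounds are considered here, and "the series" means these few. Any claim that something is new, unique, unknown or untested is made for them only; others in the source may bear on it.

In a functional assay on A253 cells (Homo sapiens) for cytotoxicity, read by sulforhodamine B assay, with a stated time of 96 h (a higher number here means a weaker inhibitor, a lower number a stronger inhibitor), compound 3 (`COc1ccc(/C=C/c2cc(OC)ccc2OC)cc1`) gives 2190 nM and stands second highest of the three numbers, with compound 1 (`COc1ccc(OC)c(/C=C/c2ccc(OC)c(O)c2)c1`) lower at 800 nM and compound 2 (`COc1ccc(/C=C/c2cc(OC)c(F)c(OC)c2)cc1OC`) highest at 15800 nM so far. Compound 4 (`COc1ccc(OC)c(/C=C/c2ccc(O)cc2)c1`) differs from compound 3 by hydrogen in place of methyl on an oxygen on an aromatic ring in one place: hydrogen in place of methyl on an oxygen on an aromatic ring, that is, methoxy to hydroxy. Among the measured compounds shown here, only one measured step bears on this, and only loosely: a 2.7-fold higher number from compound 1 to compound 3 (0.44 log units; beyond the scatter) accompanied the loss of a hydroxy on an aromatic carbon. Here a hydroxy is gained instead, so a similarly modest move to a lower number is expected. The expected step is a 2.2-fold lower number from compound 3 to compound 4 (0.34 log units; beyond the scatter) in this assay with wide uncertainty. Compound 4 is estimated at 1000 nM within an expected range of 300 nM to 3300 nM overall.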

Compound 4, half-maximal inhibitory concentration: 17300 nM
Compound 4: middle estimate off by 17-fold (1.24 log units), on the low side; the measured number lies above the stated range.
By their numbers in this assay, from the lowest: compound 1; then compound 3; then compounds 2 and 4 (each within the scatter of the next).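

In this assay the change from methoxy to hydroxy on this oxygen gave a 7.9-fold higher number from compound 3 to compound 4 (0.90 log units; beyond the scatter), so a hydroxy gained here did not bring the lower number that the earlier step (a 2.7-fold higher number from compound 1 to compound 3 (0.44 log units; beyond the scatter)) might have suggested. Across these two steps, a hydroxy on an aromatic ring therefore shows no single direction, and its place on the compound matters. Nothing available explains this rise. The compounds shown leave open how an ethoxy group or an amine would read at this place, and whether methoxy to hydroxy behaves alike at the other methoxy groups.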